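A Pyrrolidinyl Propenamide on the Oxolanyl Ether

The source may hold more compounds than are shown below. What is called first, only, known or untested is meant among the compounds shown, and "the series" means these compounds.

Compound 1 `C=CC(=O)Nc1cc2c(N3CCc4ccccc43)ncnc2cc1OC` gives 5580 nM in a functional assay on A549 cells (Homo sapiens) for antiproliferative activity, read by MTT assay, with a stated time of 72 h; on this read-out lower numbers stand for stronger inhibition and higher numbers for weaker inhibition. Compound 2 `C=CC(=O)Nc1cc2c(N3CCc4ccccc43)ncnc2cc1O[C@@H]1CCOC1`, carrying oxolan-3-yl in place of methyl on an oxygen on an aromatic ring, gives 9320 nM; the step of a 1.7-fold higher number from compound 1 to compound 2 (0.22 log units; within the scatter) lies within the scatter. Compound 3 `COc1cc2ncnc(N3CCc4ccccc43)c2cc1NC(=O)/C=C/CN1CCC(CO)CC1` gives 1980 nM. Compound 2 therefore stands at the highest of the three numbers shown, separated from compound 1 by a gap within the scatter and from compound 3 by a gap beyond it.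

Compound 4 `O=C(/C=C/CN1CCCC1)Nc1cc2c(N3CCc4ccccc43)ncnc2cc1O[C@@H]1CCOC1` differs from compound 2 in one place: 3-(pyrrolidin-1-yl)prop-1-en-1-yl in place of vinyl on a carbonyl carbon. Going by the values given here, the one measured step that bears on this change is a 2.8-fold lower number from compound 1 to compound 3 (0.45 log units; beyond the scatter), in which 3-(4-(hydroxymethyl)piperidin-1-yl)prop-1-en-1-yl replaced vinyl on a carbonyl carbon in a compound bearing methyl rather than oxolan-3-yl on the aromatic oxygen. A step of the same direction and similar, modest size is therefore expected in this assay, namely a 2.7-fold lower number from compound 2 to compound 4 (0.43 log units; beyond the scatter). Compound 4 is estimated at 3500 nM, with a likely range from 1500 nM to 8000 nM.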

Compound 4, half-maximal inhibitory concentration: 2230 nM
Compound 4: the middle estimate sits 1.6-fold (0.20 log units) above what was measured; the range from low to high includes it.
By their numbers in this assay, from the lowest: compounds 3 and 4 (each within the scatter of the next); then compounds 1 and 2 (each within the scatter of the next).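

In this assay the change from vinyl to 3-(pyrrolidin-1-yl)prop-1-en-1-yl on a carbonyl carbon gives a 4.2-fold lower number from compound 2 to compound 4 (0.62 log units; beyond the scatter) on the oxolan-3-yl ether. Going by these compounds alone, the lowering is thus no longer confined to the methyl ether, where the earlier compounds showed it as a 2.8-fold lower number from compound 1 to compound 3 (0.45 log units; beyond the scatter) with a different amine on the chain. Nothing measured here explains the lowering.

The compounds shown leave open how much depends on the ether and how much on the amine, since neither amine chain appears on both ethers. They also leave open whether dimethylamino or morpholin-4-yl in place of pyrrolidin-1-yl would give a step in the same direction.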